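The source may report more compounds than this note shows. Statements on the series, on what has been measured and on what is new or still open speak of the compounds shown alone.

Measured so far in a functional assay on CHO cells with transient receptor potential cation channel subfamily V member 1 (Rattus norvegicus) as the target; a lower number here means that less compound is needed, a higher number that more compound is needed for the effect:

Compound 1 `Cc1ccc(CC(CN/C(S)=N/Cc2cccc(NS(C)(=O)=O)c2)COC(=O)C(C)(C)C)cc1C`: 990 nM
Compound 2 `Cc1ccc(CC(CN/C(S)=N/Cc2ccc(NS(C)(=O)=O)cc2)COC(=O)c2ccccc2)cc1C`: 1730 nM
Compound 3 `CC(C)(C)c1ccc(CC(CN/C(S)=N/Cc2ccc(NS(C)(=O)=O)cc2)COC(=O)c2ccccc2)cc1`: 2790 nM

Compound 2 gives the second highest of the three numbers in this assay. Its nearest neighbour is compound 3 and its furthest is compound 1, and both gaps lie within the scatter, so the three measured compounds cannot be separated on these numbers.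

Compound 4 `COc1cc(C/N=C(\S)NCC(COC(=O)c2ccccc2)Cc2ccc(C)c(C)c2)ccc1NS(C)(=O)=O` has not yet been measured. It differs from compound 2 in one place: methoxy in place of hydrogen on an aromatic carbon. Within the data shown here, the only measured single-point step is a 1.6-fold higher number from compound 2 to compound 3 (0.21 log units; within the scatter), which swaps the group on the saturated chain carbon and leaves the ring bearing the methanesulfonamido group untouched, so it bears on compound 4 only indirectly, as a sign that a single change has so far stayed within the scatter. Among the measured compounds shown here, no measured step touches the ring where the methoxy enters, and there is no direct precedent for this change. The expected step of a 1.2-fold lower number from compound 2 to compound 4 (0.06 log units; within the scatter) is therefore taken to lie within the scatter, with no direction claimed. Compound 4 is estimated at 1500 nM in this assay, with a range from 600 nM to 4000 nM.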

Compound 4, half-maximal effective concentration: 166 nM
For compound 4 the middle estimate is 9.0-fold (0.96 log units) above the measured one, and the stated range ends above it.
By their numbers in this assay, from the lowest: compound 4; then compounds 1, 2 and 3 (each within the scatter of the next, the first and the last beyond it).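

In this assay, methoxy in place of hydrogen on an aromatic carbon ortho to a methanesulfonamido group gives the only single-place step shown that lies beyond the scatter (a 10-fold lower number from compound 2 to compound 4 (1.02 log units; beyond the scatter)), whereas the swap on the saturated chain carbon stays within it (a 1.6-fold higher number from compound 2 to compound 3 (0.21 log units; within the scatter)). The ring bearing the methanesulfonamido group, which the earlier step left untouched, is therefore a place where an entering group of 2 heavy atoms moves the number substantially, and the result sets this position apart from the saturated chain carbon within the compound 2 series. Nothing among the available data accounts for the size of this step.

On these data alone, whether the step belongs to methoxy itself or would also appear with a hydroxy, an ethoxy or a chlorine on the same aromatic carbon remains open. Also open, as far as these compounds go, is whether the same step would appear with the 4-(tert-butyl)phenyl group of compound 3 on the saturated chain carbon, or with an ester other than the benzoate shared by compound 2 and compound 4.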